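Trimethoxybenzoyl series: from aryl to arylamino

The compounds below may be only part of what the source reports. "The series", "measured", "known", "first", "only" and "open" are said of these compounds alone.

Measured in a functional assay on A549 cells (Homo sapiens) for antiproliferative activity, read by MTT assay, with a stated time of 72 h; a higher number here means a weaker inhibitor, a lower number a stronger inhibitor:
- compound 1 `COc1ccccc1-c1c(C(=O)c2cc(OC)c(OC)c(OC)c2)sc2ccccc12`: > 10000 nM, a limit
- compound 2 `COc1ccc(OC)c(-c2c(C(=O)c3cc(OC)c(OC)c(OC)c3)sc3ccccc23)c1`: > 10000 nM, a limit

Compound 2 stands at > 10000 nM, which is a limit and not a number. The whole measured picture is the limit of > 10000 nM in this assay, at which 2 of the 2 values shown sit. Among the measured compounds shown here, the one measured step, a step that the two limits leave unreadable from compound 1 to compound 2, therefore gives no size to carry forward.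

The next structure is compound 3 `CCOc1ccc(Nc2c(C(=O)c3cc(OC)c(OC)c(OC)c3)sc3ccccc23)cc1`, and the change is (4-ethoxyphenyl)amino in place of 2,5-dimethoxyphenyl on an aromatic carbon. It falls on an aromatic carbon of a five-membered aromatic ring with 1 sulfur. For the measured compounds named here, no measured step covers this exchange, so neither size nor direction rests on a measured precedent. The expectation stays weak: activity probably remains close to the limit of this assay, and a readable number could only fall on the stronger side of it.

The step expected here is an at least 2.5-fold lower number from compound 2 to compound 3 (0.39 log units; beyond the scatter). For compound 3 the estimated value is 4000 nM, with an expected range from 200 nM to 10000 nM.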

Compound 3, half-maximal inhibitory concentration: 1400 nM
The estimate for compound 3 lay 2.9-fold (0.46 log units) above the measured number; measured number inside the range.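

In this assay, this position on the five-membered aromatic ring with 1 sulfur gives its first readable number among the compounds shown once the directly attached aryl group is exchanged for an arylamino group: (4-ethoxyphenyl)amino in place of 2,5-dimethoxyphenyl gives an at least 7.1-fold lower number from compound 2 to compound 3 (0.85 log units; beyond the scatter), and in place of 2-methoxyphenyl it gives an at least 7.1-fold lower number from compound 1 to compound 3 (0.85 log units; beyond the scatter). The exchange keeps the count of 10 heavy atoms between compound 2 and compound 3 and adds 1 hydrogen-bond donor, so the gain comes with a change in linkage and not with a larger group. Both steps are floors and not full sizes: the limit of > 10000 nM in this assay, at which 2 of the 3 values shown sit.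

The compounds shown do not separate the amino link from the ethoxy group, since the two enter together. Open also is what a plain phenylamino group, a propoxy chain in place of ethoxy, or a methyl on the amino nitrogen would give.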